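Swapping the Group on Sulfur: From Compound 3 to Compound 4

The source may hold more compounds than are shown below. What is called first, only, known or untested is meant among the compounds shown, and "the series" means these compounds.

Compound 1 `FC(F)(F)c1ccc(CSc2nc(Sc3ccccn3)cc(C(F)(F)F)n2)cc1` gives 43200 nM
Compound 2 `FC(F)(F)c1ccc(CSc2nc(Sc3nnnn3-c3ccccc3)cc(C(F)(F)F)n2)cc1` gives 39500 nM
Compound 3 `FC(F)(F)c1ccc(CSc2nc(Sc3nncs3)cc(C(F)(F)F)n2)cc1` gives 8810 nM

In a functional assay on MCF7 cells (Homo sapiens) for inhibition, read by MTT assay, with a stated time of 72 h (a lower number here means a stronger inhibitor, a higher number a weaker inhibitor), compound 3 has the lowest of the three numbers (8810 nM), and its gaps to both others lie beyond the scatter. Compound 4 `FC(F)(F)c1ccc(CSc2nc(Sc3ncc(-c4ccncc4)s3)cc(C(F)(F)F)n2)cc1` keeps the shared core and changes only the group on the sulfur (5-(pyridin-4-yl)-1,3-thiazol-2-yl in place of 1,3,4-thiadiazol-2-yl on a sulfur). Three measured steps swap a group at this same place. Two were modest (a 4.9-fold lower number from compound 1 to compound 3 (0.69 log units; beyond the scatter)) and (a 4.5-fold lower number from compound 2 to compound 3 (0.65 log units; beyond the scatter)), while one stayed within the scatter (a 1.1-fold lower number from compound 1 to compound 2 (0.04 log units; within the scatter)). Going by the values given here, neither of the other two measured groups matched the 1,3,4-thiadiazol-2-yl group, but no measured compound carries the new group. A modest rise is therefore expected (a 2.3-fold higher number from compound 3 to compound 4 (0.36 log units; beyond the scatter)) in this assay as the step. The estimate for compound 4 is 20000 nM (expected range 5000 nM to 60000 nM).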

Compound 4, half-maximal inhibitory concentration: 10100 nM
Beside the measured number, compound 4's estimate is 2.0-fold (0.30 log units) above it; the measured number falls inside the stated range.
By their numbers in this assay, from the lowest: compounds 3 and 4 (each within the scatter of the next); then compounds 2 and 1 (each within the scatter of the next).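

Going by these compounds alone, the position on the sulfur tolerates a far bulkier group than the earlier compounds showed: adding a six-membered aromatic ring to the group gives only a 1.1-fold higher number from compound 3 to compound 4 (0.06 log units; within the scatter) in this assay. The larger group also keeps the lead over the other two groups, with a 3.9-fold lower number from compound 2 to compound 4 (0.59 log units; beyond the scatter) and a 4.3-fold lower number from compound 1 to compound 4 (0.63 log units; beyond the scatter). Nothing measured here accounts for these differences.

Still open, going by these compounds, is whether the pyridin-4-yl part contributes at all. A plain 1,3-thiazol-2-yl, or one carrying an amine or a carboxylic acid in its place, could settle that.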